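This account rests on a few compounds, and the source may have more. Where it says the series, first, only, none or still open, it means among the compounds named here.

Compound 1 `O=C(Nc1cc(C(F)(F)F)cc(C(F)(F)F)c1)c1cnc(Cl)nc1` is the anchor of the set. Within the data shown here, in an assay on Jurkat cells for activation of nuclear factor NF-kappa-B complex (Homo sapiens) (a higher number here means a weaker inhibitor, a lower number a stronger inhibitor), compound 1 gives 300 nM, the only number reported. The two further values are limits of the assay. Compound 2 `Cc1cc(C(=O)Nc2cc(C(F)(F)F)cc(C(F)(F)F)c2)nc(Cl)n1` gives in this assay > 10000 nM, which is a limit and not a number. Compound 3 `O=C(Nc1cc(C(F)(F)F)cc(C(F)(F)F)c1)c1cnc(-c2ccccc2)nc1` gives in this assay > 10000 nM, again a limit. Both measured steps therefore run away from compound 1: an at least 33-fold higher number from compound 1 to compound 2 (1.52 log units; beyond the scatter) and an at least 33-fold higher number from compound 1 to compound 3 (1.52 log units; beyond the scatter), both ending at the limit of > 10000 nM in this assay, at which 2 of the 3 values shown sit.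

Compound 4 `O=C(Nc1cc(C(F)(F)F)cc(C(F)(F)F)c1)c1cnc(Cl)nc1C(F)(F)F` differs from compound 1 by trifluoromethyl in place of hydrogen on an aromatic carbon. Neither measured step is this change. The step to compound 2 adds a methyl but also moves the attachment of the core to the carbonyl; the step to compound 3 replaces the chloro, which compound 4 keeps. What both steps show is that every alteration of the core of compound 1 so far has pushed the value beyond the range of this assay. For compound 4 a loss is therefore expected, its size uncertain, with a fair chance that only a limit is returned. Compound 4 is estimated at 2000 nM, within 400 nM to 10000 nM, so a step of a 6.7-fold higher number from compound 1 to compound 4 (0.82 log units; beyond the scatter) is expected.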

Compound 4, half-maximal inhibitory concentration: 50 nM
For compound 4 the middle estimate is 40-fold (1.60 log units) above the measured one; the measured number lies below the stated range.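

The core of compound 1 does allow change: trifluoromethyl in place of hydrogen, on the aromatic carbon next to the ring nitrogen and ortho to a large group, gives a 6.0-fold lower number from compound 1 to compound 4 (0.78 log units; beyond the scatter) in this assay. Among these compounds, this is the first step towards a lower number, so the earlier picture, in which each change to the core ended at a limit of the assay, holds only for compound 2 and compound 3. This position therefore accepts a group of 4 heavy atoms with the chloro group kept, although the data shown give no account of why the number falls.

With only hydrogen and trifluoromethyl shown at this position, it remains open whether the gain belongs to trifluoromethyl itself or would also appear with an ethyl group, a methoxy group or an amine. It is also open whether the chloro group is still needed once trifluoromethyl is present, since its only replacement shown, the phenyl of compound 3, sits on the core without trifluoromethyl and returns a limit rather than a number.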